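Working notes: from compound 1 to compound 3

The source may report more compounds than this note shows. Statements on the series, on what has been measured and on what is new or still open speak of the compounds shown alone.

- compound 1 `COc1cc(Nc2nc(N[C@H]3CC[C@H](N)CC3)nc3c2ncn3CCC(C)C)cc(OC)c1`: 4500 nM
- compound 2 `CCCCn1cnc2c(Nc3cc(OC)cc(OC)c3)nc(N[C@H]3CC[C@H](N)CC3)nc21`: 4500 nM

In a functional assay on MCF7 cells (Homo sapiens) for inhibition, read by fluorescence, with a stated time of 72 h (a lower number here means a stronger inhibitor of growth, a higher number a weaker inhibitor of growth), compound 1 stands level with compound 2 (4500 nM), so neither can be ranked above the other.

The next compound to be read is compound 3 `CC(C)CCn1cnc2c(Nc3ccc(O)cc3)nc(N[C@H]3CC[C@H](N)CC3)nc21`, which keeps the shared core and the chain of compound 1. The change is 4-hydroxyphenyl in place of 3,5-dimethoxyphenyl on a nitrogen on an aromatic ring. Read one bond further out, this is (3,5-dimethoxyphenyl)amino to (4-hydroxyphenyl)amino.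

Among the measured compounds shown here, only one measured step is available: no change at the digits printed from compound 1 to compound 2 (within the scatter). It concerns a saturated chain carbon, which is a different place, so it says little here. For the measured compounds named here, no measurement yet shows what a change on this nitrogen does, and any expectation is correspondingly loose.

A moderate move towards stronger growth inhibition in this assay is expected, with no change beyond the scatter still plausible. The expected step is a 2.3-fold lower number from compound 1 to compound 3 (0.35 log units; beyond the scatter) and it carries wide uncertainty. For compound 3 the estimated value is 2000 nM (expected range 500 nM to 8000 nM).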

Compound 3, concentration for 50% growth inhibition: 3100 nM
Compound 3: the middle estimate sits 1.6-fold (0.19 log units) below what was measured; measured number inside the range.
By their numbers in this assay, from the lowest: compounds 3, 1 and 2 (each within the scatter of the next).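

In this assay, among the compounds shown here, the first reading of a change on this nitrogen on an aromatic ring gives a 1.5-fold lower number from compound 1 to compound 3 (0.16 log units; within the scatter), so 4-hydroxyphenyl in place of 3,5-dimethoxyphenyl cannot be told apart from repeat scatter. The exchange is not a small one on paper: a group of 7 heavy atoms with 1 hydrogen-bond donor replaces a group of 10 heavy atoms with 0 hydrogen-bond donors, and the growth read-out still does not separate the two compounds. No supporting data bear on this result, so it stands as an observation without an explanation.

The single step changes the methoxy groups and the hydroxyl together, so the compounds shown cannot assign any contribution to either one, and a small effect from each that cancels in the sum cannot be excluded. Still open, on these data alone, is whether a plain phenyl, a 3-methoxyphenyl or a 4-aminophenyl on this nitrogen would produce a step beyond the scatter, or whether this position stays as unresponsive as these compounds suggest.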